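From a Methyl to a Nitro Group on the Benzyl Ring

The compounds below may be only part of what the source reports. "The series", "measured", "known", "first", "only" and "open" are said of these compounds alone.

Measured so far:
compound 1 `Nc1ccc(COc2ccc(OCCOCCNC3CCCC3)cc2)cc1` — 31700 nM
compound 2 `Cc1ccc(COc2ccc(OCCOCCNC3CCCC3)cc2)cc1` — 17200 nM

In a functional assay on SK-OV-3 cells (Homo sapiens) for inhibition, read by CCK-8 assay, with a stated time of 70 h (on this read-out higher numbers stand for weaker inhibition and lower numbers for stronger inhibition), compound 2 gives the lowest of the two numbers; its nearest neighbour is compound 1, and the step of a 1.8-fold lower number from compound 1 to compound 2 (0.27 log units; within the scatter) lies within the scatter, so the two compounds cannot be ranked. Compound 3 `O=[N+]([O-])c1ccccc1COc1ccc(OCCOCCNC2CCCC2)cc1` arises from compound 2 by the change (2-nitrophenyl in place of 4-methylphenyl on a saturated chain carbon bound to an oxygen on an aromatic ring). Among the compounds with values here, no measured step covers this exchange; the only step seen, a 1.8-fold lower number from compound 1 to compound 2 (0.27 log units; within the scatter), concerns a different group at a different place on the same ring, and it was small. On that slim basis, a step of similar size in either direction is expected, or none beyond the scatter, since nothing measured points one way. Compound 3 is therefore estimated at 20000 nM in this assay, within 7000 nM to 60000 nM, meaning an expected step of a 1.2-fold higher number from compound 2 to compound 3 (0.07 log units; within the scatter).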

Compound 3, half-maximal inhibitory concentration: 5370 nM
The estimate for compound 3 lay 3.7-fold (0.57 log units) above the measured number, outside the stated range (below it).
By their numbers in this assay, from the lowest: compound 3; then compounds 2 and 1 (each within the scatter of the next).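

The group on this saturated chain carbon can shift the number in this assay: 2-nitrophenyl in place of 4-methylphenyl gives a 3.2-fold lower number from compound 2 to compound 3 (0.51 log units; beyond the scatter) and stands apart from the earlier pair, which could not be ranked. In place of 4-aminophenyl, the same group gives a 5.9-fold lower number from compound 1 to compound 3 (0.77 log units; beyond the scatter) and so is separated from both earlier compounds, though both steps are modest. No measurement offered here accounts for these steps.

The exchange alters both the group and its printed ring number, so the nitro group and its location on the ring cannot yet be told apart. A 4-nitrophenyl or a 2-methylphenyl group would separate the two, while a carboxylic acid on the ring would show whether a quite different group can also move the number.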